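The source may report more compounds than this note shows. Statements on the series, on what has been measured and on what is new or still open speak of the compounds shown alone.

Measured so far in a physicochemical assay for solubility; a higher number here means a more soluble compound, a lower number a less soluble compound:
- compound 1 `CN1CCN(c2cc(C(F)(F)F)ccc2[C@H]2CCOc3cc(S(=O)(=O)Nc4nccs4)ccc32)CC1`: 176000 nM
- compound 2 `O=S(=O)(Nc1nccs1)c1ccc2c(c1)OCC[C@H]2c1ccc(C(F)(F)F)cc1-c1nccs1`: 7000 nM
- compound 3 `O=S(=O)(Nc1nccs1)c1ccc2c(c1)OCC[C@@H]2c1ccc(C(F)(F)F)cc1-c1ccc(F)cn1`: 7000 nM

Compound 2 and compound 3 stand level, and both lie well under compound 1, which gives 176000 nM. The next compound is compound 4 `O=S(=O)(Nc1nccs1)c1ccc2c(c1)OCC[C@@H]2c1ccc(C(F)(F)F)cc1-c1nccs1`, which changes one group of compound 3: 1,3-thiazol-2-yl in place of 5-fluoropyridin-2-yl on an aromatic carbon.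

Within the data shown here, only one measured step touches this place: a 25-fold lower number from compound 1 to compound 3 (1.40 log units; beyond the scatter). That step was large, but it removed 4-methylpiperazin-1-yl, a group found in neither compound 3 nor compound 4, so it offers little guide here. The new change swaps one aromatic ring with no net charge for another. Among the measured compounds shown here, compound 2 also carries 1,3-thiazol-2-yl at this place and gives 7000 nM, although it is not the same compound as compound 4 and no measured step links them.

No change beyond the scatter is therefore expected, and the estimated step is no change at the digits printed from compound 3 to compound 4 (within the scatter). The estimate for compound 4 is 7000 nM, with an expected range from 3000 nM to 15000 nM.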

Compound 4, solubility: 15000 nM
Compound 4: the middle estimate sits 2.1-fold (0.33 log units) below what was measured; measured number inside the range.
By their numbers in this assay, from the lowest: compounds 2 and 3 (each within the scatter of the next); then compound 4; then compound 1.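

In this assay, 1,3-thiazol-2-yl in place of 5-fluoropyridin-2-yl goes with a 2.1-fold higher number from compound 3 to compound 4 (0.33 log units; beyond the scatter), so even a swap between two aromatic rings with no net charge can shift the reading at this position. The pair sharing 1,3-thiazol-2-yl shows a 2.1-fold higher number from compound 2 to compound 4 (0.33 log units; beyond the scatter), and this step can be traced to the stereocentre at the saturated ring carbon alone because of one plain fact: the fact that compounds 2 and 4 differ only in the configuration as drawn. Both steps remain small beside a 12-fold lower number from compound 1 to compound 4 (1.07 log units; beyond the scatter), which goes with 1,3-thiazol-2-yl in place of 4-methylpiperazin-1-yl.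

Among the compounds shown, compounds 1 and 3 each appear in one configuration only, so it remains open whether the gap between configurations holds with other groups at this position. Also open, as far as these compounds go, is where a smaller amine such as dimethylamino, or a carboxylic acid, would fall at this position.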